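Methylating the phenol of compound 3: what to expect

A few compounds are considered here, and "the series" means these few. Any claim that something is new, unique, unknown or untested is made for them only; others in the source may bear on it.

Measured so far:
Compound 1, `COc1ccc(-c2cc3ccccc3nc2/C=C/C(=O)c2ccccc2)cc1`: 6670 nM
Compound 2, `COc1ccc(-c2cc3ccccc3nc2/C=C/C(=O)c2ccc(F)cc2)cc1`: 6990 nM
Compound 3, `COc1ccc(-c2cc3ccccc3nc2/C=C/C(=O)c2ccc(O)cc2)cc1`: 6930 nM

All three numbers come from a functional assay on NCI-H460 cells (Homo sapiens) for antiproliferative activity, read by XTT assay, with a stated time of 72 h; on this read-out lower numbers stand for stronger inhibition and higher numbers for weaker inhibition. Compound 3 sits with the second highest number of the three, but the gaps around it are tiny: the step of a 1.0-fold higher number from compound 1 to compound 3 (0.02 log units; within the scatter) and the step of a 1.0-fold lower number from compound 2 to compound 3 (0.00 log units; within the scatter) both stay inside the scatter, as does a 1.0-fold higher number from compound 1 to compound 2 (0.02 log units; within the scatter). In other words, swapping the hydrogen on the benzoyl ring for fluorine or for hydroxy left the read-out where it was.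

Compound 4, `COc1ccc(C(=O)/C=C/c2nc3ccccc3cc2-c2ccc(OC)cc2)cc1`, takes the next step from compound 3: methyl in place of hydrogen on an oxygen on an aromatic ring. Among the measured compounds shown here, no measured pair covers exactly this swap, so the only guide is the behaviour of that position so far. Every change made there, from compound 1 to compound 2 and from compound 1 to compound 3, moved nothing beyond the scatter, and a hydroxy-to-methoxy exchange is a change of similar scale at the same place. On that basis no step beyond the scatter is expected in this assay, in either direction, so the step of a 1.0-fold lower number from compound 3 to compound 4 (0.00 log units; within the scatter) is expected to be flat. Compound 4 is therefore estimated at 6900 nM, within a range of 3500 nM to 14000 nM.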

Compound 4, half-maximal inhibitory concentration: > 10000 nM
Compound 4: a limit, no number; the forecaster's own chance of this, stated with the estimate: 5%; middle value at least 1.4-fold (0.16 log units) from the limit.
By their numbers in this assay, from the lowest: compounds 1, 3 and 2 (each within the scatter of the next). At a limit, above all of these: compound 4.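

In this assay compound 4 gives > 10000 nM, which is a limit of the assay and not a number. Set against the earlier compounds, this gives an at least 1.4-fold higher number from compound 3 to compound 4 (0.15 log units; that floor lies within the scatter), an at least 1.4-fold higher number from compound 2 to compound 4 (0.15 log units; that floor lies within the scatter) and an at least 1.4-fold higher number from compound 1 to compound 4 (0.17 log units; that floor lies within the scatter), so all three steps are floors that do not by themselves move beyond the scatter. What is new is that hydrogen, fluoro and hydroxy at this place all gave numbers within the scatter of one another, while methoxy is the first group there whose true size of step remains unknown, and the position can no longer be called flat with confidence: the limit of > 10000 nM in this assay, at which 1 of the 4 values shown sits.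

The limit leaves open whether compound 4 really stands far from compounds 1, 2 and 3 or only just outside their range, and a true number would be needed to settle this. It also leaves open whether the added methyl on the oxygen is a special case, or whether an ethoxy group, an amine or a carboxylic acid at the same place would behave in the same way.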